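Ester tail variation in a Rho kinase inhibitor series

A few compounds are considered here, and "the series" means these few. Any claim that something is new, unique, unknown or untested is made for them only; others in the source may bear on it.

Compound 1 `CCCCOC(=O)c1cccc(-c2cc(C(=O)Nc3ccncc3)ccc2CN)c1`: 5.5 nM
Compound 2 `NCc1ccc(C(=O)Nc2ccncc2F)cc1-c1cccc(C(=O)OCC2CC2)c1`: 2.7 nM

Of the compounds shown here, two have been measured in an assay on isolated protein for inhibition of Rho-associated protein kinase 2 (Homo sapiens), read by radiometric assay; a lower number here means a stronger inhibitor, a higher number a weaker inhibitor. Compound 2 gives the lower of the two numbers, with 2.7 nM, while compound 1 stands higher at 5.5 nM, a gap beyond the usual scatter; the two differ in more than one place, so the pair tells nothing about any single change.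

Compound 3 `CC(C)OCCOC(=O)c1cccc(-c2cc(C(=O)Nc3ccncc3F)ccc2CN)c1` has not yet been measured. It differs from compound 2 in one place: isopropoxymethyl in place of cyclopropyl on a saturated chain carbon bound to an oxygen next to a carbonyl group. Going by the values given here, no measured pair isolates this kind of change, so the expectation rests on the two numbers alone. Both measured compounds carry an ester tail of differing shape and both sit at low values, so the change is expected to move the number little, if at all; the step of a 1.5-fold higher number from compound 2 to compound 3 (0.17 log units; within the scatter) is estimated to stay within or just beyond the scatter, toward a slightly higher number. Compound 3 is therefore expected to give about 4 nM, with a range from 1.5 nM to 12 nM.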

Compound 3, half-maximal inhibitory concentration: 37 nM
The estimate for compound 3 lay 9.3-fold (0.97 log units) below the measured number; the measured number lies above the stated range.
By their numbers in this assay, from the lowest: compound 2; then compound 1; then compound 3.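

In this assay, isopropoxymethyl in place of cyclopropyl on a saturated chain carbon bound to an oxygen next to a carbonyl group gives a 14-fold higher number from compound 2 to compound 3 (1.14 log units; beyond the scatter), so this position of the ester tail is sensitive to what is placed there, which the earlier pair, differing in more than one place, could not show. The change removes a three-membered ring of carbon and brings in an open group with one hydrogen-bond acceptor, and this single pair cannot say which of these differences matters. Nothing measured on these compounds accounts for the step.

The compounds shown leave open whether the ether oxygen or the loss of the ring goes with the higher number. A plain longer carbon chain at this place would bear on that question, and an amine at the end of the tail would show how far the position responds to other groups.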